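This account rests on a few compounds, and the source may have more. Where it says the series, first, only, none or still open, it means among the compounds named here.

Measured so far in a functional assay on K562 cells (Homo sapiens) for cytotoxicity, read by thymidine incorporation, with a stated time of 48 h; a higher number here means a weaker inhibitor, a lower number a stronger inhibitor:

Compound 1 `O=c1nc2c(cn1Cc1ccccc1)ncn2Cc1ccccc1`: > 10 ug/mL
Compound 2 `CC(C)C1c2ncn(Cc3ccccc3)c2NC(=O)N1Cc1ccccc1`: 10 ug/mL

The entry for compound 1 is a limit of the assay and not a number. Compound 1 stands at the limit of > 10 ug/mL in this assay, at which 1 of the 2 values shown sits. Compound 2, by contrast, has a true number in this assay, and it reads 10 ug/mL.

The next compound, compound 3 `O=c1nc2c(ncn2Cc2ccccc2)c(C(F)(F)F)n1Cc1ccccc1`, keeps the core of compound 1 and changes it in one place: trifluoromethyl in place of hydrogen on an aromatic carbon. The trifluoromethyl replaces a hydrogen on an aromatic carbon, ortho to a benzyl group.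

Within the data shown here, no measured pair here differs in just one place, so no earlier step shows how large such a change might be. The expectation in this assay is therefore for no shift beyond the scatter, in either direction. The estimated change is a step that the limit leaves unreadable from compound 1 to compound 3. Among the measured compounds shown here, the estimate stays close to compound 2, since its 10 ug/mL is the only true number available. For compound 3 the expected value is 12 ug/mL, with an estimated range of 5 ug/mL to 30 ug/mL.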

Compound 3, half-maximal inhibitory concentration: > 10 ug/mL
Compound 3: no number, only a limit (the forecaster's own chance of this, stated with the estimate: 55%); the middle value lies beyond the limit too.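

Compound 1 and compound 3 both give only a limit in this assay and not a number, so no step between them can be read: the limit of > 10 ug/mL in this assay, at which 2 of the 3 values shown sit.

The compounds shown leave open whether trifluoromethyl in place of hydrogen on an aromatic carbon shifts the value of the shared core at all, in either direction, and by how much.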